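Swapping the bicyclic amide headgroup of compound 2

The source may report more compounds than this note shows. Statements on the series, on what has been measured and on what is new or still open speak of the compounds shown alone.

Three sulfonyl-benzylamides were measured in an assay for inhibition of Nicotinamide phosphoribosyltransferase (Homo sapiens), read by mass spectrometry, with stated times of 15 min and 30 min; a lower number here means a stronger inhibitor, a higher number a weaker inhibitor. Compound 1 `O=C(NCc1ccc(S(=O)(=O)c2ccccc2)cc1)c1cc(-c2cccnc2)[nH]n1` gives 43 nM, compound 2 `O=C(NCc1ccc(S(=O)(=O)N2CCCCC2)cc1)c1cc2cnccc2s1` gives 150 nM, and compound 3 `Cn1c(C(=O)NCc2ccc(S(=O)(=O)c3ccccc3)cc2)cc2ccncc21` gives 410 nM. Compound 2 thus stands second highest of the three numbers: its nearest neighbour is compound 3, whose number is higher by a margin beyond the scatter, and its furthest is compound 1, whose number is lower by a margin also beyond the scatter. No two of these compounds differ in only one place, so no single step between measured compounds can be isolated.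

Compound 4 `O=C(NCc1ccc(S(=O)(=O)N2CCCCC2)cc1)c1cnc2nccn2c1` has not yet been measured. It keeps the piperidine sulfonyl benzylamide portion of compound 2 and differs in this way: a group of 9 heavy atoms (6 carbon, 3 nitrogen; one five-membered aromatic ring with 2 hetero atoms, one six-membered aromatic ring with 2 hetero atoms) in place of a group of 9 heavy atoms (7 carbon, 1 nitrogen, 1 sulfur; one five-membered aromatic ring with 1 hetero atom, one six-membered aromatic ring with 1 hetero atom), on a carbonyl carbon.

For the measured compounds named here, no measured pair shows what such a change does here, so the expectation rests on the spread of the three numbers alone. Compound 4 is expected to fall near compound 2, with a step of a 1.7-fold higher number from compound 2 to compound 4 (0.22 log units; within the scatter) that could go either way and may not exceed the scatter. The estimate for compound 4 in this assay is 250 nM, with a range from 60 nM to 1000 nM.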

Compound 4, half-maximal inhibitory concentration: 3 nM
The estimate for compound 4 lay 83-fold (1.92 log units) above the measured number; the whole stated range lies above it.
By their numbers in this assay, from the lowest: compound 4; then compound 1; then compound 2; then compound 3.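

For the compounds shown here, with the piperidine sulfonyl benzylamide portion held fixed, this assay gives a 50-fold lower number from compound 2 to compound 4 (1.70 log units; beyond the scatter) as the first step that can be read in this set, and it shows that the group on the carbonyl carbon can move this number by a large margin. The size of the step does not follow from the bulk of the group or from the kinds of rings it contains: both groups have 9 heavy atoms, one five-membered aromatic ring, one six-membered aromatic ring and 0 hydrogen-bond donors, while the entering group has 3 nitrogen and no sulfur, and 3 hydrogen-bond acceptors in place of 2. No available measurement bears on the reason for this step.

Going by these compounds, it remains open whether the same exchange would carry over to the phenyl sulfonyl benzylamide portion found in compound 1 and compound 3, as no readable step links either of them to compound 4. Also open, on these data alone, is what a morpholine in place of the piperidine, or an amine or a methyl on the group at the carbonyl carbon, would do in this assay to the number.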